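This account rests on a few compounds, and the source may have more. Where it says the series, first, only, none or still open, it means among the compounds named here.

In a functional assay on Jurkat cells (Homo sapiens) for antiproliferative activity, read by MTT assay, with a stated time of 72 h (on this read-out higher numbers stand for weaker inhibition and lower numbers for stronger inhibition), compound 1, `COc1ccc(-c2ncnn2-c2cc(OC)c(OC)c(OC)c2)cc1`, gives 50 nM. Compound 3, `COc1cc(-n2ncnc2-c2ccccc2)cc(OC)c1OC`, gives in this assay only a limit of the method, > 10000 nM. The step from compound 3 to compound 1 is a single change, (methoxy in place of hydrogen on an aromatic carbon), and it is large: an at least 200-fold lower number from compound 3 to compound 1 (2.30 log units; beyond the scatter). Compound 2, `COc1cc(-c2ncnn2-c2ccccc2)cc(OC)c1OC`, is built from the same atoms as compound 3 joined differently; the difference between the two cores is not broken down here. Compound 2 likewise reaches only a limit of this assay, > 10000 nM. Within the data shown here, two of the three numbers so far therefore sit at the same boundary, (the limit of > 10000 nM in this assay, at which 2 of the 3 values shown sit), so the true gap from compound 3 to compound 1 is known only as a least value.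

Compound 4, `COc1ccc(-n2ncnc2-c2cc(OC)c(OC)c(OC)c2)cc1`, is not yet measured. It arises from compound 2 by methoxy in place of hydrogen on an aromatic carbon, the same change that turns compound 3 into compound 1, at the same place. By analogy with that earlier step, the expected step in this assay is an at least 33-fold lower number from compound 2 to compound 4 (1.52 log units; beyond the scatter), resting on compound 2 with > 10000 nM and the large step seen in compound 1. Compound 4 is thus estimated at 300 nM, within 30 nM to 5000 nM.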

Compound 4, half-maximal inhibitory concentration: 93 nM
The estimate for compound 4 lay 3.2-fold (0.51 log units) above the measured number, and the stated range covers the measured number.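

In this assay, going from phenyl to 4-methoxyphenyl on this core gives an at least 100-fold lower number from compound 2 to compound 4 (2.03 log units; beyond the scatter), so the change that was large on the core of compound 1 is also large on the core of compound 4. Compound 2 gives > 10000 nM, which is a limit of the assay and not a number. The change therefore carries over between these two cores in direction and in being large, but its true size on each core stays unknown, and two cores are too few to show a rule for the whole series: the same change on two cores in this assay, an at least 200-fold lower number (2.30 log units; beyond the scatter) from compound 3 to compound 1 and an at least 100-fold lower number (2.03 log units; beyond the scatter) from compound 2 to compound 4; the limit leaves it open whether they differ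

The compounds shown carry only hydrogen or methoxy at this place, so it remains open whether a hydroxyl, an amine or a longer chain such as ethoxy would serve as well as methoxy. They also leave open how the number would move if the methoxy groups on the other ring were replaced by other groups.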